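The compounds below may be only part of what the source reports. "The series", "measured", "known", "first", "only" and "open" are said of these compounds alone.

Measured so far, in a functional assay on SMMC-7721 cells (Homo sapiens) for antiproliferative activity, read by MTT assay, with a stated time of 72 h; on this read-out higher numbers stand for weaker inhibition and lower numbers for stronger inhibition:
compound 1 `CCC(=O)N(C)c1ccc2[nH]c(-c3n[nH]c4ccccc34)cc2n1`, giving 33500 nM
compound 2 `CN(C(=O)c1ccc([N+](=O)[O-])cc1)c1ccc2[nH]c(-c3n[nH]c4ccccc34)cc2n1`, giving 18400 nM

For the measured compounds named here, compound 2 holds the lower of the two numbers, yet its only neighbour is compound 1, and the step of a 1.8-fold lower number from compound 1 to compound 2 (0.26 log units; within the scatter) lies within the scatter, so the two compounds are not separated by these data. Compound 3 `CN(C(=O)Nc1ccccc1)c1ccc2[nH]c(-c3n[nH]c4ccccc34)cc2n1` differs from compound 2 in one place: anilino in place of 4-nitrophenyl on a carbonyl carbon. Going by the values given here, the one measured step that bears on this carbonyl carbon, a 1.8-fold lower number from compound 1 to compound 2 (0.26 log units; within the scatter), stayed within the scatter, which suggests that the substituent on this carbon has so far moved this assay little. Among the compounds with values here, no measured step tests the anilino group itself, and a hydrogen-bond donor enters where none stood before, so the expectation rests on a single, flat comparison. For compound 3 the estimated step of a 1.2-fold higher number from compound 2 to compound 3 (0.08 log units; within the scatter) is not expected to go beyond the scatter in either direction. Compound 3 is therefore expected near 22000 nM, with a range of 7000 nM to 70000 nM.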

Compound 3, half-maximal inhibitory concentration: 280 nM
Compound 3: middle estimate off by 79-fold (1.90 log units), on the high side; the whole stated range lies above it.
By their numbers in this assay, from the lowest: compound 3; then compounds 2 and 1 (each within the scatter of the next).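

In this assay the carbonyl carbon proves to be a sensitive position: anilino in place of 4-nitrophenyl gives a 66-fold lower number from compound 2 to compound 3 (1.82 log units; beyond the scatter) and anilino in place of ethyl gives a 120-fold lower number from compound 1 to compound 3 (2.08 log units; beyond the scatter) on the same carbon. Both steps are large and run the same way from two different groups, whereas ethyl and 4-nitrophenyl could not be told apart, and compound 2 also carries a six-membered aromatic ring of carbon only, so that ring alone does not go with the low number. No measurement at hand accounts for the size of these steps.

Open, on these data alone, is whether the steps go with the hydrogen-bond donor that enters with anilino or with the anilino group as a whole; a phenoxy or cyclohexylamino group on this carbonyl carbon would bear on that. Also open, as far as these compounds go, is how a chloro or methoxy group on the anilino ring would read.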